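The source may hold more compounds than are shown below. What is called first, only, known or untested is meant among the compounds shown, and "the series" means these compounds.

Measured compounds:
compound 1 `COc1cncc(-c2c(C)nn(-c3nc(-c4ccc(Cl)c(Cl)c4)c(SC(C)C)s3)c2C(=O)O)c1`, 21000 nM
compound 2 `Cc1nn(-c2nc(-c3ccc(Cl)c(Cl)c3)c(SC(C)C)s2)c(C(=O)O)c1-c1cncc(C#N)c1`, 20000 nM
compound 3 `COc1ccccc1-c1c(C)nn(-c2nc(-c3ccc(Cl)c(Cl)c3)c(SC(C)C)s2)c1C(=O)O`, 14700 nM

All three were tested in a functional assay on BJAB cells (Homo sapiens) for antiproliferative activity, with a stated time of 4 days; on this read-out higher numbers stand for an effect only at larger amounts of compound and lower numbers for an effect already at smaller amounts. Compound 3 sits at the low end of the three numbers, but since a 1.4-fold lower number from compound 1 to compound 3 (0.15 log units; within the scatter) and a 1.4-fold lower number from compound 2 to compound 3 (0.13 log units; within the scatter) are both within the scatter, the three compounds cannot really be told apart in this assay.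

Compound 4 `COc1cc(Cl)cc(-c2c(C)nn(-c3nc(-c4ccc(Cl)c(Cl)c4)c(SC(C)C)s3)c2C(=O)O)c1` is not yet measured. It differs from compound 3 in one place: 3-chloro-5-methoxyphenyl in place of 2-methoxyphenyl on an aromatic carbon. The two steps that touch the same position, a 1.4-fold lower number from compound 1 to compound 3 (0.15 log units; within the scatter) and a 1.4-fold lower number from compound 2 to compound 3 (0.13 log units; within the scatter), swapped one ring for another without moving the number beyond the scatter. Among the compounds with values here, no measured step shows what adding a chlorine to this ring does, so there is no ground to expect a change beyond the scatter in this assay in either direction.

Compound 4 is therefore estimated to give about 15000 nM, with a likely range from 7000 nM to 32000 nM. The step this estimate implies, a 1.0-fold higher number from compound 3 to compound 4 (0.01 log units; within the scatter), is expected to stay within the scatter.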

Compound 4, half-maximal effective concentration: 760 nM
Compound 4: middle estimate off by 20-fold (1.30 log units), on the high side, outside the stated range (below it).
By their numbers in this assay, from the lowest: compound 4; then compounds 3, 2 and 1 (each within the scatter of the next).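

In this assay the ring at this position clearly matters: 3-chloro-5-methoxyphenyl gives a 19-fold lower number from compound 3 to compound 4 (1.29 log units; beyond the scatter) and a 26-fold lower number from compound 2 to compound 4 (1.42 log units; beyond the scatter) and also a 28-fold lower number from compound 1 to compound 4 (1.44 log units; beyond the scatter) even though the swaps among the rings of compounds 1, 2 and 3 stayed within the scatter. The flat picture from those three compounds therefore held only for their own rings and does not describe the position as a whole. No measured information accounts for this large step.

Compared with compound 3, compound 4 adds a chlorine and also carries its methoxy group at a different ring position, so the compounds shown cannot separate these two changes. A 3-chlorophenyl or 3-methoxyphenyl ring would test each change alone, while a 3-bromo-5-methoxyphenyl ring would ask whether the chlorine can be replaced.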